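This account rests on a few compounds, and the source may have more. Where it says the series, first, only, none or still open, it means among the compounds named here.

Measured compounds:
compound 1, `COC(=O)[C@@]1(C)CCC=C2[C@@H]1CC[C@@H](C)[C@]2(C)Cc1c[nH]c2ccc(Br)cc12`, in a functional assay on HBL-100 cells (Homo sapiens) for inhibition, read by sulforhodamine B assay, with a stated time of 48 h (a lower number here means a stronger inhibitor of growth, a higher number a weaker inhibitor of growth), compound 1 gives 16000 nM
compound 2, `COC(=O)[C@@]1(C)CCC=C2[C@@H]1CC[C@@H](C)[C@]2(C)Cc1c[nH]c2ccc(Cl)cc12`, in this assay compound 2 gives 17000 nM
compound 3, `COC(=O)[C@@]1(C)CCC=C2[C@@H]1CC[C@@H](C)[C@]2(C)Cc1c(C)[nH]c2c(Br)cccc12`, in this assay compound 3 gives 27000 nM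

Compounds 1 and 2 share one core and differ in a single place: chloro in place of bromo on an aromatic carbon. The step this change made is a 1.1-fold higher number from compound 1 to compound 2 (0.03 log units; within the scatter), so the two values say the same thing about growth inhibition. Compound 3 carries a different core; how it differs from the core of compound 1 is not broken down here. Its value stands beside those of compound 1 and compound 2 without a separating gap in this assay.

Compound 4, `COC(=O)[C@@]1(C)CCC=C2[C@@H]1CC[C@@H](C)[C@]2(C)Cc1c(C)[nH]c2c(Cl)cccc12`, has not yet been measured. It is made from compound 3 by chloro in place of bromo on an aromatic carbon. Among the measured compounds shown here, this is the same kind of change as the one from compound 1 to compound 2, but the place is not the same: in compound 3 the aromatic carbon is ortho to a fused ring and meta to a fused ring, while in compound 1 it is meta to a fused ring and para to a fused ring.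

Because the earlier step of a 1.1-fold higher number from compound 1 to compound 2 (0.03 log units; within the scatter) was small, compound 4 is expected to stay close to compound 3, with an expected step of a 1.1-fold higher number from compound 3 to compound 4 (0.03 log units; within the scatter). The estimate for compound 4 in this assay is 29000 nM, expected to lie between 15000 nM and 55000 nM.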

Compound 4, concentration for 50% growth inhibition: 22000 nM
Compound 4: the middle estimate sits 1.3-fold (0.12 log units) above what was measured; measured number inside the range.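

In this assay, chloro in place of bromo on an aromatic carbon gave a 1.2-fold lower number from compound 3 to compound 4 (0.09 log units; within the scatter), so compound 3 and compound 4 say the same thing about growth inhibition. Set beside the earlier step, the exchange reads alike on both cores: the same change on two cores in this assay, a 1.1-fold higher number (0.03 log units; within the scatter) from compound 1 to compound 2 and a 1.2-fold lower number (0.09 log units; within the scatter) from compound 3 to compound 4, 1.3-fold (0.12 log units) apart, within the scatter of two such steps. This shows that, in these two pairs, the exchange of the two halogens left the number within the scatter on either core; it does not show that the exchange would stay as small on any other core, and since the halogen sits at a different place on the aromatic ring in each pair, the core and the place cannot be told apart.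

The compounds shown carry only bromo or chloro on the aromatic ring, so it stays open whether a fluoro, a methoxy or an amine at these places would move the number in this series. All four also share the methyl ester, and what a carboxylic acid or an amide in its place would do to growth inhibition remains an open question.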